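Dropping the chloro from an inactive hydrazone

The source may report more compounds than this note shows. Statements on the series, on what has been measured and on what is new or still open speak of the compounds shown alone.

Compound 1 `COc1ccc(OC)c(/C=C/c2nnc(Nc3ccc(Cl)cc3)o2)c1` carries a chloro-substituted aniline on its heterocycle. In a functional assay on CAKI-1 cells (Homo sapiens) for antiproliferative activity, read by sulforhodamine B assay, with a stated time of 48 h (on this read-out higher numbers stand for weaker inhibition of growth and lower numbers for stronger inhibition of growth), compound 1 gives > 100000 nM, which is a limit of the assay rather than a number. Compound 2 `COc1ccc(OC)c(/C=C/C(=O)N/N=C/c2ccc(Cl)cc2)c1` replaces that heterocycle with an acylhydrazone linker. In this assay compound 2 gives > 100000 nM, again a limit and not a measured number. Where compound 2 stands is therefore set by the limit of > 100000 nM in this assay, at which 2 of the 2 values shown sit, so nothing separates it from the other value shown.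

Compound 3 `COc1ccc(OC)c(/C=C/C(=O)N/N=C/c2ccccc2)c1` is the unmeasured analogue. It differs from compound 2 only in hydrogen in place of chloro on an aromatic carbon. Within the data shown here, no step between measured compounds is available to guide this change. The expected step that the limit leaves unreadable from compound 2 to compound 3 is none beyond the scatter, given that the parent sits at a limit. Compound 3 is thus expected to give about 150000 nM, with a range from 40000 nM to 500000 nM, most likely reported again only as a limit.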

Compound 3, concentration for total growth inhibition: 6660 nM
Compound 3: middle estimate off by 23-fold (1.35 log units), on the high side, and the stated range ends above it.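

Exchanging chloro for hydrogen at this place, on the six-membered aromatic ring and para to a large group, gives an at least 15-fold lower number from compound 2 to compound 3 (1.17 log units; beyond the scatter) in this assay. Compound 3, at 6660 nM, is the only compound shown with a measured number, so this single change from 4-chlorophenyl to phenyl separates a compound with a readable effect on growth from one without, which compound 1 and compound 2 alone could not show. On these data alone, the true size of the step remains unknown because compound 2 gives only a limit: the limit of > 100000 nM in this assay, at which 2 of the 3 values shown sit.

As far as these compounds go, whether a fluoro, a methyl or an amine at this place would hold the value of compound 3 or fall back to the limit stays open. So does whether replacing the chloro on the aniline of compound 1 with hydrogen would have a similar effect.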